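This account rests on a few compounds, and the source may have more. Where it says the series, first, only, none or still open, it means among the compounds named here.

Working notes on the series.

The three measured compounds share one core and differ in the aryl hydrazone end. Compound 1 `O=C(COc1cccc2ccccc12)N/N=C/c1ccc(Cl)cc1` is the reference for this note. In an ADME assay on HEL cells (Homo sapiens) for cytotoxicity (on this read-out lower numbers stand for higher toxicity in this test and higher numbers for lower toxicity in this test), compound 1 gives 100 ug/mL, the highest of the three numbers recorded. Compound 3 `COc1ccc(/C=N/NC(=O)COc2cccc3ccccc23)cc1O` gives 27.7 ug/mL in this assay, the nearest number to compound 1, and the gap between the two is beyond the scatter. Compound 2 `C/C(=N\NC(=O)COc1cccc2ccccc12)c1cccc([N+](=O)[O-])c1` gives 10.5 ug/mL in this assay, the furthest from compound 1, again beyond the scatter. Within the data shown here, no single-point step between measured compounds is available, so the size of any one change in this assay has not been seen directly.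

Compound 4 `O=C(COc1cccc2ccccc12)N/N=C/c1ccc(Br)cc1` is not yet measured. It differs from compound 1 by bromo in place of chloro on an aromatic carbon. Nothing among the measured compounds speaks to this particular exchange, and on the numbers shown there is no basis for expecting a move beyond the scatter in either direction. The step from compound 1 to compound 4 is therefore estimated as a 1.3-fold lower number from compound 1 to compound 4 (0.10 log units; within the scatter), which is taken as no real change. Compound 4 is accordingly expected to give about 80 ug/mL in this assay, with a range from 40 ug/mL to 160 ug/mL.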

Compound 4, half-maximal cytotoxic concentration: 100 ug/mL
For compound 4 the middle estimate is 1.3-fold (0.10 log units) below the measured one; measured number inside the range.
By their numbers in this assay, from the lowest: compound 2; then compound 3; then compounds 1 and 4 (each within the scatter of the next).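

Among these compounds, this is the first single-point step: in this assay, bromo in place of chloro on an aromatic carbon gives no change at the digits printed from compound 1 to compound 4 (within the scatter), so the size of one change at this position has now been seen directly. Among the compounds shown here, at this place in the shared core, para to a large group, the 4-chlorophenyl and 4-bromophenyl ends cannot be told apart in this read-out, and the exchange of one of these halogens for the other is the only change at this position whose size is known. No measurement at hand accounts for this absence of a change, and the result stands as an observation only.

On these data alone, what an amine or a carboxylic acid at this same place would do to the number in this assay stays open, as does whether fluoro or iodo would read alike with chloro and bromo. Also open, as far as these compounds go, is whether the same exchange of chloro for bromo would show no change on an aromatic ring elsewhere in the molecule or at another position on this ring.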